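Hydroxymethyl to Carboxy Swap on Two Related Cores

The source may report more compounds than this note shows. Statements on the series, on what has been measured and on what is new or still open speak of the compounds shown alone.

Compound 1 `Cn1nc(Cc2nnc(SCC(=O)Nc3ccc(Cl)cc3Cl)n2CCCO)c2ccccc2c1=O` and compound 2 `Cn1nc(Cc2nnc(SCC(=O)Nc3ccc(Cl)cc3Cl)n2CCC(=O)O)c2ccccc2c1=O` share one core; compound 3 `Cn1c(Cc2nn(CCCO)c(=O)c3ccccc23)nnc1SCC(=O)Nc1ccc(Cl)cc1Cl` and compound 4 `Cn1c(Cc2nn(CCC(=O)O)c(=O)c3ccccc23)nnc1SCC(=O)Nc1ccc(Cl)cc1Cl` share another, built from the same atoms joined differently. The difference between the two cores is not broken down here. In an assay on 32D cells for inhibition of interleukin-15 (Mus musculus), read by resazurin assay, with stated times of 30 min and 2.5 days, in the presence of a further agent that is not named here (a higher number here means a weaker inhibitor, a lower number a stronger inhibitor), compound 1 gives only a limit, > 30000 nM. Compound 2 likewise gives only a limit in this assay, > 30000 nM. Compound 3 also reaches only a limit in this assay, > 30000 nM. The change from compound 1 to compound 2 is carboxy in place of hydroxymethyl on a saturated chain carbon, two bonds along the chain from an aromatic nitrogen; the step it made is a step that the two limits leave unreadable from compound 1 to compound 2, unreadable because of the limit of > 30000 nM in this assay, at which 3 of the 3 values shown sit. The change from compound 3 to compound 4 is the same change, (carboxy in place of hydroxymethyl on a saturated chain carbon, two bonds along the chain from an aromatic nitrogen), on the other core. With every value shown sitting at a limit, nothing measured points to a readable gain from this change. The step from compound 3 to compound 4 in this assay is expected to be a step that the limit leaves unreadable from compound 3 to compound 4, resting on compound 1 and compound 2, whose step that the two limits leave unreadable from compound 1 to compound 2 stayed beyond the limit. Compound 4 is therefore expected to give about 60000 nM in this assay, most likely again reported only as a limit, within 20000 nM to 200000 nM.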

Compound 4, half-maximal inhibitory concentration: > 30000 nM
Compound 4: no number, only a limit; the forecaster's own chance of this, stated with the estimate: 85%; the middle value does not contradict the limit.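

No step can be read between compound 3 and compound 4 in this assay, because both values are limits and not numbers: the limit of > 30000 nM in this assay, at which 4 of the 4 values shown sit.

The compounds shown leave open what the change from hydroxymethyl to carboxy does on either core and how the two cores compare; none of the four yields a number.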